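Replacing a Ring with an Acid-Tipped Chain

The source may report more compounds than this note shows. Statements on the series, on what has been measured and on what is new or still open speak of the compounds shown alone.

Measured so far:
compound 1, `O=C(Nc1ccc2[nH]cc(C3CCN(CCCCCCCCCN4CCC(c5c[nH]c6ccc(NC(=O)c7ccc(F)cc7)cc56)CC4)CC3)c2c1)c1ccc(F)cc1`, 126 nM
compound 2, `O=C(Nc1ccc2[nH]cc(C3CCN(CCN4CCCCC4)CC3)c2c1)c1ccc(F)cc1`, > 1000 nM

Of the compounds shown here, two have been measured in an assay on CHO-K1 cells for displacement of a labelled ligand from 5-hydroxytryptamine receptor 1B (Homo sapiens), read by scintillation counting; on this read-out lower numbers stand for stronger inhibition and higher numbers for weaker inhibition. Compound 1 gives 126 nM. Compound 2 gives only a limit, > 1000 nM; this is the limit of > 1000 nM in this assay, at which 1 of the 2 values shown sits, not a measured number, so where compound 2 truly stands is not known beyond that.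

Compound 3, `O=C(O)CCCCCCCCCN1CCC(c2c[nH]c3ccc(NC(=O)c4ccc(F)cc4)cc23)CC1`, has not yet been measured. It differs from compound 2 in one place: 7-carboxyheptyl in place of piperidin-1-yl on a saturated chain carbon, two bonds along the chain from an amine nitrogen in a ring. For the measured compounds named here, no measured pair shows this change on its own, so nothing in the data tells how large an effect to expect from it. Because compound 2 sits at the limit of > 1000 nM in this assay, at which 1 of the 2 values shown sits, any step from it can only be estimated loosely. In this assay the step that the limit leaves unreadable from compound 2 to compound 3 is expected to stay within the usual scatter. The value expected for compound 3 in this assay is 1500 nM, with a range from 300 nM to 8000 nM.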

Compound 3, inhibition constant: > 1000 nM
Compound 3: a limit, no number; the forecaster's own chance of this, stated with the estimate: 55%; the middle value lies beyond the limit too.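

In this assay, for the compounds shown here, no step from compound 2 to compound 3 can be read, because each gives only a limit and not a number: the limit of > 1000 nM in this assay, at which 2 of the 3 values shown sit. Where compound 2 and compound 3 truly stand, and whether 7-carboxyheptyl in place of piperidin-1-yl changes anything, stays open.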